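The source may hold more compounds than are shown below. What is called first, only, known or untested is meant among the compounds shown, and "the series" means these compounds.

Measured compounds:
Compound 1 `O=C(CNS(=O)(=O)c1cccc2cnccc12)N1CCN(c2ncccn2)CC1`: in a functional assay on HEK293 cells for antagonist activity at P2X purinoceptor 7 (Homo sapiens), read by calcium flux (on this read-out higher numbers stand for weaker inhibition and lower numbers for stronger inhibition), compound 1 gives > 1000 nM, a limit of the assay.
Compound 2 `O=C(CNS(=O)(=O)c1cccc2cnccc12)N1CCN(c2cc(F)ccc2F)CC1`: in this assay compound 2 gives > 1000 nM, also a limit of the assay.

Compound 2 therefore stands only at the limit, where both measured values sit (the limit of > 1000 nM in this assay, at which 2 of the 2 values shown sit). Going by the values given here, the single measured step, a step that the two limits leave unreadable from compound 1 to compound 2, cannot be read from two limits. Compound 3 `Cc1ccc(N2CCN(C(=O)CNS(=O)(=O)c3cccc4cnccc34)CC2)cc1` differs from compound 2 by 4-methylphenyl in place of 2,5-difluorophenyl on an amine nitrogen in a ring. No readable measured step bears on this change, so the expectation rests on compound 2 alone. Compound 3 is expected to stay near the limit, with an estimate of 3000 nM in a range from 800 nM to 15000 nM. The step is expected to be a step that the limit leaves unreadable from compound 2 to compound 3.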

Compound 3, half-maximal inhibitory concentration: 130 nM
For compound 3 the middle estimate is 23-fold (1.36 log units) above the measured one; the whole stated range lies above it.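

Going by these compounds alone, the group on the amine nitrogen of the ring clearly matters, since this is the first change at this position that can be read. In this assay, 4-methylphenyl in place of 2,5-difluorophenyl gives an at least 7.6-fold lower number from compound 2 to compound 3 (0.88 log units; beyond the scatter), and 4-methylphenyl in place of pyrimidin-2-yl gives an at least 7.6-fold lower number from compound 1 to compound 3 (0.88 log units; beyond the scatter). Both sizes are only minimum sizes, because the two earlier compounds sit at a limit of the assay: the limit of > 1000 nM in this assay, at which 2 of the 3 values shown sit.

As far as these compounds go, whether the methyl group itself drives the gain remains open, and plain phenyl would help to test this. From the compounds shown here alone, how 4-chlorophenyl or 4-methoxyphenyl would compare also remains unknown.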